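The source may hold more compounds than are shown below. What is called first, only, known or untested is meant among the compounds shown, and "the series" means these compounds.

Measured compounds:

compound 1 `Nc1scc(CN2CCN(c3cccnc3)CC2)c1C(=O)c1ccc(Cl)cc1`, which gives 0% in an assay on CHO cells for displacement of a labelled ligand from adenosine receptor A1 (Homo sapiens), read by scintillation counting, with a stated time of 120 min, tested at 10 uM; a lower number here means less inhibition, a higher number more inhibition at the concentration tested (going by the name of the read-out)
compound 2 `Nc1scc(CN2CCN(c3c(F)cccc3F)CC2)c1C(=O)c1ccc(Cl)cc1`, which gives 1% in this assay

Compound 2 stands at the higher of the two numbers shown, but its step from compound 1, a number 1 percentage points higher from compound 1 to compound 2 (within the scatter), is within the scatter, so the two compounds cannot be told apart on these numbers. Both give a number close to zero inhibition in this assay at the concentration tested.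

The next compound, compound 3 `Nc1scc(CN2CCN(c3cc(F)ccc3F)CC2)c1C(=O)c1ccc(Cl)cc1`, differs from compound 2 in a single place: 2,5-difluorophenyl in place of 2,6-difluorophenyl on an amine nitrogen in a ring. For the measured compounds named here, the only measured step that bears on this site is the one from compound 1 to compound 2, where the group on the ring amine nitrogen was exchanged, and that step, a number 1 percentage points higher from compound 1 to compound 2 (within the scatter), was within the scatter. With the group on this nitrogen already swapped once without a step beyond the scatter, and the change to compound 3 being a shift of the same two fluorine atoms around the phenyl ring, no step beyond the scatter is expected in this assay in either direction.

Compound 3 is therefore expected to give about 1% in this assay, with a likely range from -8% to 10%. The expected step from compound 2 to compound 3 is no change at the digits printed from compound 2 to compound 3 (within the scatter), that is, essentially no change.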

Compound 3, a percentage reported as inhibition, at one concentration (the size of the read-out at that concentration, not a potency): 1%
Compound 3: middle estimate and measured number agree at the digits printed; measured number inside the range.
By their numbers in this assay, from the lowest: compounds 1, 2 and 3 (each within the scatter of the next).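

In this assay, the step that moves the fluorine atoms, from 2,6-difluorophenyl to 2,5-difluorophenyl on the amine nitrogen in a ring, is no change at the digits printed from compound 2 to compound 3 (within the scatter), so at this position the two fluorine patterns cannot be told apart, something the earlier pair, which exchanged one ring for another, could not show. The comparison with pyridin-3-yl at the same nitrogen is a number 1 percentage points higher from compound 1 to compound 3 (within the scatter), which means that a second difluorophenyl group also cannot be told apart from that nitrogen-containing ring, and the finding from the first exchange no longer rests on a single fluorine pattern. No measurement is available that would explain why these groups read alike.

All three compounds give numbers close to zero at the one concentration tested, so these results do not show whether any group at this nitrogen can move the number beyond the scatter. From the compounds shown here alone, a phenyl ring carrying a carboxylic acid or an aminomethyl group, or a longer alkyl chain in place of the ring, would test this position more widely, and changes elsewhere on the shared core remain open as well.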